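From carboxy to ethoxycarbonyl on a shared core

The source may hold more compounds than are shown below. What is called first, only, known or untested is meant among the compounds shown, and "the series" means these compounds.

Measured in a functional assay on the whole organism (strain Sprague-Dawley) for inhibition, with Rattus norvegicus as the target, with a stated time of 10 min; on this read-out lower numbers stand for an effect already at smaller amounts and higher numbers for an effect only at larger amounts of compound:
Compound 1 `O=C(O)c1cnc(-c2ccccc2)[nH]c1=O` gives 50 mg/kg
Compound 2 `Cn1c(-c2ccccc2)ncc(C(=O)O)c1=O` gives 50 mg/kg

Compound 2 stands level with compound 1 in this assay and has no other neighbour on these numbers. The next compound, compound 3 `CCOC(=O)c1cnc(-c2ccccc2)n(C)c1=O`, replaces carboxy with ethoxycarbonyl, that is, ethyl in place of hydrogen on an oxygen next to a carbonyl group. Among the compounds with values here, only one measured step exists, methyl in place of hydrogen on an aromatic nitrogen, and it shows no change at the digits printed from compound 1 to compound 2 (within the scatter) at another place in the molecule. Going by these compounds, no measured change touches the carboxy group, so that step offers weak guidance and the direction stays open. The expected step is a 1.2-fold higher number from compound 2 to compound 3 (0.08 log units; within the scatter) and nothing beyond the scatter is firmly expected, though with wide uncertainty. For compound 3 the estimated value is 60 mg/kg (expected range 15 mg/kg to 200 mg/kg).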

Compound 3, dose for 50% inhibition: > 5 mg/kg
Compound 3: a limit, no number; the forecaster's own chance of this, stated with the estimate: 35%; the middle value is on the limit's open side.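

In this assay, within the data shown here, compound 3 gives > 5 mg/kg, which is a limit and not a number, so no step from compound 2 to compound 3 can be read. The compounds shown leave open where compound 3 stands relative to compound 2, and so what ethoxycarbonyl in place of carboxy does on this read-out.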